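A Carbonyl Enters Where a Chlorophenyl Leaves

A few compounds are considered here, and "the series" means these few. Any claim that something is new, unique, unknown or untested is made for them only; others in the source may bear on it.

Three compounds have so far been tested in a functional assay on SGC-7901 cells (Homo sapiens) for antiproliferative activity, read by MTT assay, with a stated time of 24 h; a higher number here means a weaker inhibitor, a lower number a stronger inhibitor:
Compound 1 `O=C(NNc1cccc(Cl)c1)c1ccc(NS(=O)(=O)c2cnc(O)nc2O)cc1` gives 11600 nM.
Compound 2 `Cc1ccccc1NNC(=O)c1cccc(NS(=O)(=O)c2cnc(O)nc2O)c1` reaches only the limit of this assay, > 20000 nM.
Compound 3 `O=C(NNc1ccccc1F)c1cccc(NS(=O)(=O)c2cnc(O)nc2O)c1` likewise reaches only the limit, > 20000 nM.

In this assay, for the measured compounds named here, compound 1 therefore holds the only actual number; the other two results are limits, since (the limit of > 20000 nM in this assay, at which 2 of the 3 values shown sit). Going by the values given here, the one comparable step, a step that the two limits leave unreadable from compound 2 to compound 3, is unreadable: both of its ends sit at the limit. Compound 4 `O=C(NNC(=O)c1ccc(NS(=O)(=O)c2cnc(O)nc2O)cc1)c1ccc(F)cc1` is compound 1 with a single change: (4-fluorophenyl)carbonyl in place of 3-chlorophenyl on an amine nitrogen. Among the compounds with values here, no measured step touches this change, and the unreadable step offers no guidance either. The expectation therefore rests on the number of compound 1, 11600 nM, taken with a wide spread. It also allows for a real chance that compound 4 ends where compounds 2 and 3 did, at the limit of this assay. Compound 4 is estimated at 15000 nM, between 5000 nM and 45000 nM. This corresponds to an expected step of a 1.3-fold higher number from compound 1 to compound 4 (0.11 log units; within the scatter), a change not expected to rise beyond the scatter.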

Compound 4, half-maximal inhibitory concentration: > 20000 nM
Compound 4: only a limit was reported; the forecaster's own chance of this, stated with the estimate: 45%; at least 1.3-fold (0.12 log units) between middle value and limit.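

In this assay compound 4 gives > 20000 nM, which is a limit of the assay and not a number. For the compounds shown here, putting (4-fluorophenyl)carbonyl in place of 3-chlorophenyl on the amine nitrogen gives an at least 1.7-fold higher number from compound 1 to compound 4 (0.23 log units; that floor lies within the scatter), so this is the first readable step at this position, though its true size stays unknown and the printed floor does not clear the usual scatter. The larger carbonyl-bearing group brings no measured number, and compound 1 remains the only compound with one: the limit of > 20000 nM in this assay, at which 3 of the 4 values shown sit.

The carbonyl and the fluorine arrive together in this change, so the result cannot be assigned to either one alone. Still open, as far as these compounds go, is how a plain benzoyl group, an acetyl group or a 4-fluorophenyl group without the carbonyl would read on that amine nitrogen.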